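This account rests on a few compounds, and the source may have more. Where it says the series, first, only, none or still open, it means among the compounds named here.

Series notes, one step. The shared core of compound 1 `CCCn1c(=O)c2nc(-c3cnn(Cc4cc(C(F)(F)F)ccc4Cl)c3)[nH]c2n(CCC)c1=O` carries a benzyl on a saturated chain carbon bound to an aromatic nitrogen. In an assay on CHO cells for displacement of a labelled ligand from adenosine receptor A1 (Homo sapiens) (on this read-out higher numbers stand for weaker inhibition and lower numbers for stronger inhibition), compound 1 gives 1200 nM. Compound 2 `CCCn1c(=O)c2nc(-c3cnn(Cc4ccccc4C(F)(F)F)c3)[nH]c2n(CCC)c1=O` gives 44 nM in this assay, and the step of a 27-fold lower number from compound 1 to compound 2 (1.44 log units; beyond the scatter) shows how much the substitution on that benzyl matters here. Compound 3 `CCCn1c(=O)c2nc(-c3cnn(Cc4cccc(F)c4F)c3)[nH]c2n(CCC)c1=O` has no result in this assay: its reading is "not determined" (no result reported), so there is no single number on which it stands. Compound 4 `CCCn1c(=O)c2nc(-c3cnn(Cc4ccccc4C)c3)[nH]c2n(CCC)c1=O` differs from compound 3 by 2-methylphenyl in place of 2,3-difluorophenyl on a saturated chain carbon bound to an aromatic nitrogen. Among the compounds with values here, no measured step covers this pair; only the large step from compound 1 to compound 2 shows that a single group on this benzyl can shift this assay strongly, in either direction. Compound 4 is therefore expected at 90 nM, with a range of 20 nM to 500 nM.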

Compound 4, inhibition constant: 22 nM
Estimate against measurement, compound 4: 4.1-fold (0.61 log units) above; measured number inside the range.
By their numbers in this assay, from the lowest: compounds 4 and 2 (each within the scatter of the next); then compound 1.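

In this assay, the step of a 2.0-fold lower number from compound 2 to compound 4 (0.30 log units; within the scatter) leaves methyl and trifluoromethyl on an aromatic carbon of this benzyl indistinguishable. The step of a 55-fold lower number from compound 1 to compound 4 (1.74 log units; beyond the scatter), with 2-methylphenyl in place of 2-chloro-5-(trifluoromethyl)phenyl, sets compound 1 apart from both compound 2 and compound 4, so a small group on the benzyl is tolerated as well as trifluoromethyl. No measurement offered here explains this.

Steps to compound 3 cannot be read. Going by these compounds, whether the chloro or the second trifluoromethyl of compound 1 accounts for its place remains open, as does how an amine or a carboxylic acid on this benzyl would read.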